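The compounds below may be only part of what the source reports. "The series", "measured", "known", "first", "only" and "open" are said of these compounds alone.

Compound 3 `COc1cc(/C=C/C(=O)C2=C(/C=C/c3ccc(O)c(OC)c3)NC(=S)NC2c2ccc(C)cc2)ccc1O` gives 62% in a functional assay, with a stated time of 20 min, tested at 50 uM; a higher number here means a stronger effect of the compound at the concentration tested, a lower number a weaker effect. Among the three measured compounds this places compound 3 second; compound 2 `COc1cc(/C=C/C(=O)C2=C(/C=C/c3ccc(O)c(OC)c3)NC(=O)NC2c2cccc([N+](=O)[O-])c2)ccc1O` gives 71%, and the two values lie within the scatter of each other, while compound 1 `COc1cc(/C=C/C(=O)C2=C(/C=C/c3ccc(O)c(OC)c3)NC(=O)NC2c2ccc(C)cc2)ccc1O` gives 46%, a gap beyond the scatter that puts compound 3 clearly above compound 1. Among the compounds with values here, the only measured step on record, a number 25 percentage points higher from compound 1 to compound 2 (beyond the scatter), concerns the aryl group on the saturated ring carbon of the shared core and shows that a change there can move the number modestly.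

Compound 4 `COc1cc(/C=C/C(=O)C2=C(/C=C/c3ccc(O)c(OC)c3)NC(=S)NC2c2ccc(N(C)C)cc2)ccc1O` differs from compound 3 at the same aryl group: dimethylamino in place of methyl on an aromatic carbon. Within the data shown here, no measured pair here exchanges a methyl for a dimethylamino group, so the direction of the effect is not known from these data. Among the measured compounds shown here, because the one step on record, a number 25 percentage points higher from compound 1 to compound 2 (beyond the scatter), was modest and the new change is of a comparable size, compound 4 is expected to fall in the same band as compound 3 rather than far from it. The step of a number 2 percentage points lower from compound 3 to compound 4 (within the scatter) is therefore estimated to stay within the scatter. For compound 4 the expected value in this assay is 60%, with a range from 40% to 78%.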

Compound 4, a percentage reported as activity, at one concentration (the size of the read-out at that concentration, not a potency): 89.5%
Compound 4: middle estimate off by 29.5 percentage points, on the low side; the whole stated range lies below it.
By their numbers in this assay, from the lowest: compound 1; then compounds 3 and 2 (each within the scatter of the next); then compound 4.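

In this assay, the step of a number 27.5 percentage points higher from compound 3 to compound 4 (beyond the scatter) shows that the aryl group on the saturated ring carbon also responds to change when the core carries the thiocarbonyl, and that the response can occur without moving the substituent to a different place on the ring: 4-(dimethylamino)phenyl simply replaces 4-methylphenyl. Together with a number 25 percentage points higher from compound 1 to compound 2 (beyond the scatter), it gives two modest steps, each beyond the scatter and each upward on leaving 4-methylphenyl, although the two steps have different cores and different incoming groups, so they do not amount to a general rule. No supporting measurement is available that could account for the size or direction of this step.

The compounds shown leave open whether the higher number depends on the dimethylamino group itself, since a primary amine, a methoxy group or a diethylamino group at the same place could tell whether the nitrogen or the size of its substituents matters. They also leave open whether 4-(dimethylamino)phenyl gives a similar step on the core with the carbonyl, where only 4-methylphenyl and 3-nitrophenyl appear.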